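Carboxyphenyl replacement on the shared core of compound 3

This account rests on a few compounds, and the source may have more. Where it says the series, first, only, none or still open, it means among the compounds named here.

Compound 1 `N#Cc1ccccc1-c1ccc(CSc2ncnc3ccccc23)cc1` reaches in an assay on isolated protein for inhibition of phosphodiesterase 7 (Homo sapiens), read by scintillation proximity assay and cAMP accumulation, with a stated time of 1 h (a lower number here means a stronger inhibitor, a higher number a weaker inhibitor), only a limit, > 100000 nM. Compound 2 `N#Cc1ccccc1-c1ccc(CSc2nc(SCc3ccc([N+](=O)[O-])cc3)nc3ccccc23)cc1`, which carries a (4-nitrobenzyl)sulfanyl in place of hydrogen on an aromatic carbon, likewise gives only a limit, > 100000 nM. The step that the two limits leave unreadable from compound 1 to compound 2 therefore cannot be read. Compound 3 `COC(=O)c1cccc(-c2ccc(CSc3nc(C(C)C)nc4ccccc34)cc2)c1` also stands at a limit in this assay, > 100000 nM. Within the data shown here, all three values sit at the limit of > 100000 nM in this assay, at which 3 of the 3 values shown sit, so the series so far contains no readable step of any size.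

Compound 4 `CC(C)c1nc(SCc2ccc(-c3ccc(C(=O)O)cc3)cc2)c2ccccc2n1` differs from compound 3 by 4-carboxyphenyl in place of 3-(methoxycarbonyl)phenyl on an aromatic carbon. Among the measured compounds shown here, no measured step bears on this change, and the one step that exists between measured compounds is itself unreadable, so nothing supports an expected gain or loss. The step that the limit leaves unreadable from compound 3 to compound 4 is therefore expected to stay within the scatter, with a high chance that only a limit is reported again. Compound 4 is expected to give 150000 nM in this assay, with a range from 30000 nM to 1000000 nM.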

Compound 4, half-maximal inhibitory concentration: 930 nM
Beside the measured number, compound 4's estimate is 160-fold (2.21 log units) above it; the measured number lies below the stated range.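

In this assay, among these compounds, the change to 4-carboxyphenyl gives an at least 100-fold lower number from compound 3 to compound 4 (2.03 log units; beyond the scatter), the only readable step. It shows that this place, on an aromatic carbon para to a large group, can respond strongly to the choice of substituent, which compound 1, compound 2 and compound 3 could not show with limits alone. Compound 4 is the only compound shown with a measured number rather than a limit, and the others remain at one limit: the limit of > 100000 nM in this assay, at which 3 of the 4 values shown sit.

The step swaps methoxycarbonyl for a carboxylic acid and changes the substitution from 3- to 4- at once, so the compounds shown do not separate these two changes. From the compounds shown here alone, whether a primary amide or a tetrazole in place of the carboxylic acid would keep the number remains open.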